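The source may hold more compounds than are shown below. What is called first, only, known or untested is meant among the compounds shown, and "the series" means these compounds.

Compound 1 `C=C(Br)C(=O)Nc1cccc(-c2cn3nc(Cc4cccc(OC)c4)sc3n2)c1` gives 3100 nM in a functional assay on CCRF-CEM cells (Homo sapiens) for inhibition, read by cell counting, with a stated time of 3 days; on this read-out higher numbers stand for weaker inhibition and lower numbers for stronger inhibition. Compound 3 `CCc1ccc(-c2nn3cc(-c4cccc(N)c4)nc3s2)cc1` gives 22000 nM in this assay. Compound 2 `Nc1cccc(-c2cn3nc(-c4ccc(F)cc4)sc3n2)c1` returns only a limit of the assay in this assay, >= 250000 nM, so compound 2 stands at that limit rather than at a number (the limit of >= 250000 nM in this assay, at which 1 of the 3 values shown sits). The change from compound 2 to compound 4 `Nc1cccc(-c2cn3nc(Cc4ccccc4)sc3n2)c1` is benzyl in place of 4-fluorophenyl on an aromatic carbon. Within the data shown here, the one measured step that starts from compound 2 is an at least 11-fold lower number from compound 2 to compound 3 (1.05 log units; beyond the scatter), which moved downward from the limit. Compound 4 is therefore expected to leave the limit as well, and its estimate is 50000 nM, with a range from 10000 nM to 250000 nM. For compound 4 this estimate means an expected at least 5.0-fold lower number from compound 2 to compound 4 (0.69 log units; beyond the scatter).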

Compound 4, half-maximal inhibitory concentration: 37000 nM
Beside the measured number, compound 4's estimate is 1.4-fold (0.13 log units) above it, and the stated range covers the measured number.
By their numbers in this assay, from the lowest: compound 1; then compounds 3 and 4 (each within the scatter of the next). At a limit, above all of these: compound 2.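

In this assay, benzyl in place of 4-fluorophenyl on this aromatic carbon gives an at least 6.7-fold lower number from compound 2 to compound 4 (0.82 log units; beyond the scatter), so a second replacement, after the ethyl-bearing ring of compound 3, also moves off the limit. Compound 2 holds a limit and not a number, so this step is a bound: the limit of >= 250000 nM in this assay, at which 1 of the 4 values shown sits.

This change removes the fluoro and adds a carbon between the two rings at once, and the compounds shown do not separate the two. As far as these compounds go, a 4-fluorobenzyl group or a longer chain such as phenethyl at this carbon remains open.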